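Para substituent swap on the aryl oxadiazole indole series

The source may report more compounds than this note shows. Statements on the series, on what has been measured and on what is new or still open speak of the compounds shown alone.

Measured so far:
Compound 1 `Fc1ccc(-c2noc(Cc3c[nH]c4ccccc34)n2)cc1` — in a functional assay on cells (Splenocyte, Mus musculus, strain BALB/c) for inhibition, read by scintillation counting and thymidine incorporation, with stated times of 48 h and 8 h (on this read-out higher numbers stand for weaker inhibition and lower numbers for stronger inhibition), compound 1 gives 5400 nM.
Compound 2 `Clc1ccc(-c2noc(Cc3c[nH]c4ccccc34)n2)cc1` — in this assay compound 2 gives 22600 nM.

Compound 2 holds the highest number of the two; the step of a 4.2-fold higher number from compound 1 to compound 2 (0.62 log units; beyond the scatter) sets it apart from compound 1. Compound 3 `O=[N+]([O-])c1ccc(-c2noc(Cc3c[nH]c4ccccc34)n2)cc1` is not yet measured. Change from compound 2: nitro in place of chloro on an aromatic carbon. Going by the values given here, no measured step replaces chloro with nitro, so the one step known, a 4.2-fold higher number from compound 1 to compound 2 (0.62 log units; beyond the scatter), bears only loosely. For compound 3 the expected step is a 1.5-fold lower number from compound 2 to compound 3 (0.18 log units; within the scatter), with no clear direction in this assay beyond the scatter. Compound 3 is therefore estimated at 15000 nM, expected between 4000 nM and 60000 nM.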

Compound 3, half-maximal inhibitory concentration: > 50000 nM
Compound 3 ended at the assay's limit; the forecaster's own chance of this, stated with the estimate: 15%; middle value at least 3.3-fold (0.52 log units) from the limit.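

In this assay compound 3 reads > 50000 nM, a limit of the assay and not a number. Nitro in place of chloro gives an at least 2.2-fold higher number from compound 2 to compound 3 (0.34 log units; beyond the scatter), and nitro in place of fluoro gives an at least 9.2-fold higher number from compound 1 to compound 3 (0.96 log units; beyond the scatter), so this position para to a large group tolerates neither change without a loss of inhibition beyond the scatter. Across the three compounds, fluoro gives the strongest inhibition, and the true size of both nitro steps stays unknown. As far as these compounds go, whether an amine or a carboxylic acid at this position would give a lower number than compound 1 remains open.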